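Swapping the Aryl Group on Compound 3

The source may hold more compounds than are shown below. What is called first, only, known or untested is meant among the compounds shown, and "the series" means these compounds.

Compound 1 `COc1cc(C2=NOC(COc3ccc(-c4nnnn4-c4cc(OC)c(OC)c(OC)c4)cc3N)C2)cc(OC)c1OC`: 2060 nM
Compound 2 `COc1ccc(F)c(C2=NOC(COc3ccc(-c4nnnn4-c4cc(OC)c(OC)c(OC)c4)cc3N)C2)c1`: 1510 nM
Compound 3 `COc1ccc(C2=NOC(COc3ccc(-c4nnnn4-c4cc(OC)c(OC)c(OC)c4)cc3N)C2)cc1[N+](=O)[O-]`: 2220 nM

In a functional assay on A549 cells (Homo sapiens) for cytotoxicity, read by MTT assay, with a stated time of 48 h (on this read-out lower numbers stand for stronger inhibition and higher numbers for weaker inhibition), compound 3 gives 2220 nM, which cannot be told apart from the values of compound 1 and compound 2 given the usual scatter. Compound 4 `COc1cc(-n2nnnc2-c2ccc(OCC3CC(c4ccc(C(F)(F)F)cc4)=NO3)c(N)c2)cc(OC)c1OC` carries 4-(trifluoromethyl)phenyl in place of 4-methoxy-3-nitrophenyl, on a carbon with a double bond to nitrogen (4-(trifluoromethyl)phenyl in place of 4-methoxy-3-nitrophenyl on a carbon with a double bond to nitrogen).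

Three measured steps exchange the group at this same place: a 1.4-fold lower number from compound 1 to compound 2 (0.13 log units; within the scatter), a 1.1-fold higher number from compound 1 to compound 3 (0.03 log units; within the scatter) and a 1.5-fold higher number from compound 2 to compound 3 (0.17 log units; within the scatter). All three are small and lie within the scatter. Going by the values given here, none of the measured compounds carries a trifluoromethyl group, so these steps offer only indirect guidance. On this evidence, no step beyond the scatter is expected in this assay, and no direction can be assigned. The expected change is a 1.2-fold lower number from compound 3 to compound 4 (0.07 log units; within the scatter). For compound 4 the estimated value is 1900 nM, with an expected range of 950 nM to 3800 nM.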

Compound 4, half-maximal inhibitory concentration: 1220 nM
The estimate for compound 4 lay 1.6-fold (0.19 log units) above the measured number, within the range that was stated.
By their numbers in this assay, from the lowest: compounds 4, 2, 1 and 3 (each within the scatter of the next).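

In this assay, 4-(trifluoromethyl)phenyl gives a 1.8-fold lower number from compound 3 to compound 4 (0.26 log units; within the scatter), and comparison with the other two aryl groups gives a 1.2-fold lower number from compound 2 to compound 4 (0.09 log units; within the scatter) and a 1.7-fold lower number from compound 1 to compound 4 (0.23 log units; within the scatter). Compound 4 is the first of these compounds with no methoxy group on the aryl ring at this carbon and no hydrogen-bond acceptor in the group there, and even this change does not move the number beyond the scatter. No measurement shown here accounts for the result.

As far as these compounds go, all four compounds carry a substituted phenyl ring at this place, so it remains open how a cyclohexyl ring, or a phenyl ring bearing a dimethylamino group or a carboxylic acid, would behave. Since none of the steps exceeds the scatter, the compounds shown also leave open which group, if any, would clearly shift the number in this assay.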